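This account rests on a few compounds, and the source may have more. Where it says the series, first, only, none or still open, it means among the compounds named here.

Measured compounds:
- compound 1 `COC(=O)[C@@H]1OC2(CCN(c3nc(=O)c4cc(C(F)(F)F)cc([N+](=O)[O-])c4s3)CC2)O[C@H]1c1ccccc1`: in an ADME assay on HUVEC cells (Homo sapiens) for antiproliferative activity, with a stated time of 72 h (a higher number here means a weaker inhibitor of growth, a lower number a stronger inhibitor of growth), compound 1 gives > 50000 nM
- compound 2 `O=c1nc(N2CCN(c3nccs3)CC2)sc2c([N+](=O)[O-])cc(C(F)(F)F)cc12`: compound 2 gives "not determined" (no result reported)
- compound 3 `O=c1nc(N2CCC(F)(F)CC2)sc2c([N+](=O)[O-])cc(C(F)(F)F)cc12`: compound 3 gives "not determined" (no result reported)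

Standing of compound 3: no number exists for it in this assay; of the other two entries one is a limit and one carries no result. Going by the values given here, the value of compound 1 is a limit of this assay, not a number, and it marks the only point of reference so far (the limit of > 50000 nM in this assay, at which 1 of the 3 values shown sits). Among the compounds with values here, no pair of measured compounds differing in one place exists, so no measured step is available.

Compound 4 `Cc1ccc(CNc2nc(=O)c3cc(C(F)(F)F)cc([N+](=O)[O-])c3s2)n1C` carries ((1,5-dimethyl-1H-pyrrol-2-yl)methyl)amino in place of 4,4-difluoropiperidin-1-yl on an aromatic carbon. Within the data shown here, with no measured step to lean on, the size and direction of the change from compound 3 to compound 4 in this assay cannot be anchored; the expectation is framed only by the single limit seen for compound 1 (the limit of > 50000 nM in this assay, at which 1 of the 3 values shown sits). Compound 4 is therefore expected near 30000 nM, in an estimated range from 5000 nM to 100000 nM, with a real chance that only a limit is reported.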

Compound 4, concentration for 50% growth inhibition: 17000 nM
Compound 4: the middle estimate sits 1.8-fold (0.25 log units) above what was measured, within the range that was stated.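

No step can be read from compound 3 to compound 4: in this assay compound 3 has no value, and compound 4, at 17000 nM, has no measured partner differing in one place. The compounds shown leave open what replacing 4,4-difluoropiperidin-1-yl with ((1,5-dimethyl-1H-pyrrol-2-yl)methyl)amino does to growth inhibition.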